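Chloro in place of nitrile on a weakly active core

The source may hold more compounds than are shown below. What is called first, only, known or untested is meant among the compounds shown, and "the series" means these compounds.

Compound 1 `CNc1nc(C#N)nc(NC2(C#N)CCCCC2)n1` is known in an in vitro assay on Sf21 cells for inhibition of high affinity 3',5'-cyclic-AMP phosphodiesterase 7A (Homo sapiens) (a higher number here means a weaker inhibitor, a lower number a stronger inhibitor), only as a limit: in this assay compound 1 gives > 1000 nM, which is the limit of > 1000 nM in this assay, at which 1 of the 3 values shown sits. Compound 2 `CNc1nc(NC2(C#N)CCCCC2)nc(-n2cncn2)n1` carries 1H-1,2,4-triazol-1-yl in place of cyano on an aromatic carbon and also reaches only a limit, and in this assay compound 2 gives > 5000 nM. Compound 3 `CNc1nc(NC2(C#N)CCCCC2)nc(N2CCCC2)n1` carries pyrrolidin-1-yl in place of cyano on an aromatic carbon and likewise reaches only a limit, and in this assay compound 3 gives > 5000 nM. Two of the three values therefore sit at the limit of > 5000 nM in this assay, at which 2 of the 3 values shown sit. The steps a step that the two limits leave unreadable from compound 1 to compound 2 and a step that the two limits leave unreadable from compound 1 to compound 3 cannot be sized, and neither can a step that the two limits leave unreadable from compound 2 to compound 3.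

Compound 4 `CNc1nc(Cl)nc(NC2(C#N)CCCCC2)n1` differs from compound 1 by chloro in place of cyano on an aromatic carbon. Going by the values given here, none of the measured steps shows what a chloro on this carbon does, and the three known values give only a floor for weak inhibition. Compound 4 is therefore expected to remain a weak inhibitor, with an estimated 3000 nM and a range from 500 nM to 20000 nM. This implies an expected step that the limit leaves unreadable from compound 1 to compound 4 in this assay, which is estimated to be small.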

Compound 4, half-maximal inhibitory concentration: 1070 nM
Estimate against measurement, compound 4: 2.8-fold (0.45 log units) above; low and high end bracket the measured number.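

In this assay, the group on this carbon does move the read-out: chloro in place of pyrrolidin-1-yl gives an at least 4.6-fold lower number from compound 3 to compound 4 (0.66 log units; beyond the scatter), and chloro in place of 1H-1,2,4-triazol-1-yl gives an at least 4.6-fold lower number from compound 2 to compound 4 (0.66 log units; beyond the scatter). The true size of both steps stays unknown, because compound 2 and compound 3 stand only at a limit: the limit of > 5000 nM in this assay, at which 2 of the 4 values shown sit. The step from compound 1 to compound 4 cannot be read, because compound 1 also stands only at a limit: the limit of > 1000 nM in this assay, at which 1 of the 4 values shown sits.

As far as these compounds go, whether chloro or nitrile gives the lower number on this carbon remains open. From the compounds shown here alone, it is also open whether bromo, methoxy, a primary amine or a carboxylic acid in this place would give a lower number than chloro on the shared core.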